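Hydroxyphenyl amides: moving the hydroxyl on the anilide ring

The source may report more compounds than this note shows. Statements on the series, on what has been measured and on what is new or still open speak of the compounds shown alone.

Measured compounds, in a functional assay on NUGC-3 cells (Homo sapiens) for inhibition, read by sulforhodamine B assay, with a stated time of 48 h; on this read-out higher numbers stand for weaker inhibition of growth and lower numbers for stronger inhibition of growth:
Compound 1, `O=C(Nc1cccc(O)c1)C1c2ccccc2CCN1C(=O)c1ccc(Cl)cc1`: > 10000 nM, a limit of the assay.
Compound 2, `O=C(Nc1ccc(C(F)(F)F)cc1)C1NCCc2ccccc21`: 4220 nM.
Compound 3, `O=C(Nc1cccc(O)c1)C1NCCc2ccccc21`: > 10000 nM, a limit of the assay.

Compound 1 stands at the edge of what this assay reports: the limit of > 10000 nM in this assay, at which 2 of the 3 values shown sit. The step from compound 1 to compound 3, a step that the two limits leave unreadable from compound 1 to compound 3, is unreadable because both compounds sit at that limit. Within the data shown here, compound 2 is the only compound with a number.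

Compound 4, `O=C(Nc1ccc(O)cc1)C1c2ccccc2CCN1C(=O)c1ccc(Cl)cc1`, differs from compound 1 by 4-hydroxyphenyl in place of 3-hydroxyphenyl on an amide-type nitrogen. Among the measured compounds shown here, no measured pair varies the hydroxyl position on the anilide ring, so no measured step bears directly on this change. With compound 1 at a limit and nothing to say the change would lift potency, the expectation for compound 4 is that it stays near the same limit in this assay, so the expected step that the limit leaves unreadable from compound 1 to compound 4 is small. The estimated value for compound 4 is 15000 nM, expected to fall between 5000 nM and 50000 nM, most likely reported again as a limit.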

Compound 4, concentration for 50% growth inhibition: > 10000 nM
Compound 4 was reported as a limit (the forecaster's own chance of this, stated with the estimate: 70%); the middle value is on the limit's open side.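

Among these compounds, compound 1 and compound 4 both sit at a limit of the assay, so no step between them can be read: the limit of > 10000 nM in this assay, at which 3 of the 4 values shown sit. The compounds shown leave open whether 3-hydroxyphenyl and 4-hydroxyphenyl differ at all on the amide-type nitrogen of this shared core.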